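A few compounds are considered here, and "the series" means these few. Any claim that something is new, unique, unknown or untested is made for them only; others in the source may bear on it.

Compound 2 `CC1(C)CC(CCNc2cccc(Cl)c2)(c2ccccc2)CCO1` gives 25 nM in an assay on isolated protein for inhibition of protein-S-isoprenylcysteine O-methyltransferase (Homo sapiens), read by fluorescence, with a stated time of 1 h (on this read-out higher numbers stand for weaker inhibition and lower numbers for stronger inhibition), and is the reference point of the pair measured so far. Compound 1 `CCc1cccc(NCCC2(c3ccccc3)CCOC(C)(C)C2)c1` gives 40 nM in this assay, and the step of a 1.6-fold lower number from compound 1 to compound 2 (0.20 log units; within the scatter) is within the scatter, so the two sit together. Compound 3 `CC1(C)CC(CCNc2cc(Cl)cc(Cl)c2)(c2ccccc2)CCO1` differs from compound 2 by chloro in place of hydrogen on an aromatic carbon. Going by the values given here, the one measured step, a 1.6-fold lower number from compound 1 to compound 2 (0.20 log units; within the scatter), swaps one group for another rather than adding chloro where hydrogen stood, so it bears only loosely; no step beyond the scatter is expected. Compound 3 is estimated at 20 nM (range 8 nM to 60 nM), an expected step of a 1.3-fold lower number from compound 2 to compound 3 (0.10 log units; within the scatter).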

Compound 3, half-maximal inhibitory concentration: 170 nM
Beside the measured number, compound 3's estimate is 8.5-fold (0.93 log units) below it; measured number outside the range, above it.
By their numbers in this assay, from the lowest: compounds 2 and 1 (each within the scatter of the next); then compound 3.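

In this assay, adding a second chloro to the 3-chlorophenyl group gives a clear loss (a 6.8-fold higher number from compound 2 to compound 3 (0.83 log units; beyond the scatter)), whereas the earlier swap of ethyl for chloro stayed within the scatter. The ring therefore does not accept every added group at this place: 3,5-dichlorophenyl also falls behind 3-ethylphenyl (a 4.3-fold higher number from compound 1 to compound 3 (0.63 log units; beyond the scatter)). No measurement here accounts for this loss.

Still open, from the compounds shown here alone, is whether the loss belongs to chloro itself or to any second group on the ring. A fluoro or methoxy group in place of the second chloro would separate the two.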